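The source may hold more compounds than are shown below. What is called first, only, known or untested is meant among the compounds shown, and "the series" means these compounds.

In an ADME assay on LLC-MK2 cells (Macaca mulatta) for cytotoxicity, read by spectrophotometry and crystal violet staining, with a stated time of 4 days (a lower number here means that less compound is tolerated, a higher number that more compound is tolerated), compound 2 `CC(C)n1ncc2c(C(=O)Nc3ncccn3)cc(-c3cccs3)nc21` gives 75000 nM, the highest of the three numbers shown. Compound 1 `CC(C)n1ncc2c(C(=O)Nc3ncccn3)cc(-c3ccsc3)nc21` gives 50000 nM, and compound 3 `CC(C)n1ncc2c(C(=O)Nc3ccc(F)cc3)cc(C3CC3)nc21` gives 12500 nM. Within the data shown here, the only step between close neighbours is a 1.5-fold higher number from compound 1 to compound 2 (0.18 log units; within the scatter). Compound 4 `CC(C)n1ncc2c(C(=O)Nc3cccc(S(N)(=O)=O)c3)cc(-c3cccs3)nc21` differs from compound 2 in this way: 3-sulfamoylphenyl in place of pyrimidin-2-yl on an amide-type nitrogen. Among the measured compounds shown here, no measured step bears on such a change: the one step concerns a substituent on an aromatic carbon, not the group on the amide-type nitrogen, and compound 3 differs from compound 2 in two places, so its value shows only that another amide substituent combined with a second change gave a lower number. The expected step in this assay is a 1.5-fold lower number from compound 2 to compound 4 (0.18 log units; within the scatter), with no direction beyond the scatter foreseen. Compound 4 is estimated at 50000 nM, between 15000 nM and 100000 nM.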

Compound 4, half-maximal cytotoxic concentration: 25000 nM
Compound 4: middle estimate off by 2.0-fold (0.30 log units), on the high side; measured number inside the range.
By their numbers in this assay, from the lowest: compounds 3, 4, 1 and 2 (each within the scatter of the next, the first and the last beyond it).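

In this assay, 3-sulfamoylphenyl in place of pyrimidin-2-yl on the amide-type nitrogen gives a 3.0-fold lower number from compound 2 to compound 4 (0.48 log units; beyond the scatter). This is the only single change shown at this position, and it shows that the group on the amide-type nitrogen can move this number beyond the scatter, which the thiophene step on the aromatic carbon did not. Nothing available accounts for this step.

On these data alone, it remains open whether the step belongs to the carbon-only ring or to its sulfamoyl group. A plain phenyl, or a phenyl carrying a carboxylic acid or an amine, on the same nitrogen with thiophen-2-yl kept would bear on that question.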